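A few compounds are considered here, and "the series" means these few. Any claim that something is new, unique, unknown or untested is made for them only; others in the source may bear on it.

Measured in an ADME assay on the whole organism (Mus musculus, strain CD-1) for pharmacokinetics, at a dose of 10 mg/kg by the oral route; a higher number here means more compound in the circulation at the dose given, a lower number less compound in the circulation:

- compound 1 `COc1cc([C@](O)(CCN(C)C)[C@@H](c2cc3cc(Br)ccc3nc2OC)c2cccc(OC)c2F)cc(OC(C)C)n1` gives 9000 ng.h/mL
- compound 2 `COc1cc([C@](O)(CCN(C)C)[C@@H](c2cc3cc(Br)ccc3nc2OC)c2cccc(OC)c2F)cc(SC)n1` gives 4600 ng.h/mL
- compound 3 `COc1cc([C@](O)(CCN(C)C)[C@@H](c2cc3cc(C#N)ccc3nc2OC)c2cccc(OC)c2F)cc(SC)n1` gives 1100 ng.h/mL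

Of these three numbers, the lowest belongs to compound 3 . The next compound to be examined is compound 4 `CCSc1cc([C@](O)(CCN(C)C)[C@@H](c2cc3cc(C#N)ccc3nc2OC)c2cccc(OC)c2F)cc(SCC)n1`, which differs from compound 3 by a group of 12 heavy atoms (9 carbon, 1 nitrogen, 2 sulfur; one six-membered aromatic ring with 1 hetero atom) in place of a group of 10 heavy atoms (7 carbon, 1 nitrogen, 1 oxygen, 1 sulfur; one six-membered aromatic ring with 1 hetero atom), on a saturated chain carbon bound to an oxygen on a saturated carbon and two saturated chain carbons. Among the compounds with values here, no measured compound carries the entering group, so the evidence for this change is indirect. Within the data shown here, the closest precedent is the exchange of isopropoxy for methylsulfanyl, a 2.0-fold lower number from compound 1 to compound 2 (0.29 log units; within the scatter), a step within the scatter. The exchange of bromo for cyano, a 4.2-fold lower number from compound 2 to compound 3 (0.62 log units; beyond the scatter), is a modest step beyond the scatter, but it does not bear directly on the new change, since the cyano group stays in place in compound 4 . It does set the level from which compound 4 starts. As far as these compounds go, on this basis no step beyond the scatter is expected in this assay, and the direction remains open. The estimated step is a 1.2-fold lower number from compound 3 to compound 4 (0.09 log units; within the scatter). For compound 4 the expected value is 900 ng.h/mL, with an estimated range from 300 ng.h/mL to 2600 ng.h/mL.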

Compound 4, area under the concentration-time curve: 1400 ng.h/mL
The estimate for compound 4 lay 1.6-fold (0.19 log units) below the measured number; measured number inside the range.
By their numbers in this assay, from the lowest: compounds 3 and 4 (each within the scatter of the next); then compounds 2 and 1 (each within the scatter of the next).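

In this assay, putting the group of 12 heavy atoms in place of the group of 10 heavy atoms, on a saturated chain carbon bound to an oxygen on a saturated carbon and two saturated chain carbons, gives a 1.3-fold higher number from compound 3 to compound 4 (0.10 log units; within the scatter). This is the first step shown at this place, and with the cyano group held constant, this exchange of one oxygen for a second sulfur and two more carbons leaves the two numbers within the scatter of each other. Nothing available bears on the reason for this result.

The compounds shown leave open whether the same exchange would read alike with bromo in place of cyano. They also leave open how a ring carrying an amine or a carboxylic acid would fare at this place.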